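This account rests on a few compounds, and the source may have more. Where it says the series, first, only, none or still open, it means among the compounds named here.

Measured compounds:
compound 1, `Cc1c(OCCCCOc2cccc(C(=O)O)c2)ccc(C(=O)CC2CCCC2)c1O`, 92.9%
compound 2, `Cc1c(OCCCCOc2ccc(C(=O)O)cc2)ccc(C(=O)CC(C)C)c1O`, 51.9%
compound 3, `Cc1c(OCCCCOc2cccc(C(=O)O)c2)ccc(C(=O)CC(C)C)c1O`, 69.9%

In an assay on HEK293 cells for positive allosteric modulation of metabotropic glutamate receptor 3 (Rattus norvegicus), read by thallium flux, with a stated time of 2.5 min (a higher number here means a larger maximal response, a lower number a smaller maximal response), compound 1 gives the highest of the three numbers. Compound 3 is the nearest to it, a number 23 percentage points lower from compound 1 to compound 3 (beyond the scatter), and compound 2 is the furthest, with 51.9% set against compound 1 at 92.9%. The other measured step, a number 18 percentage points higher from compound 2 to compound 3 (beyond the scatter), concerns the ring carrying the carboxylic acid.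

Compound 4, `Cc1cc(C(=O)O)ccc1OCCCCOc1ccc(C(=O)CC2CCCC2)c(O)c1C`, differs from compound 1 in one place: 4-carboxy-2-methylphenyl in place of 3-carboxyphenyl on an oxygen on a saturated carbon. Of the measured steps only a number 18 percentage points higher from compound 2 to compound 3 (beyond the scatter) bears on this change, as it exchanges 4-carboxyphenyl and 3-carboxyphenyl on the same oxygen; read in the opposite direction it points to a drop of similar size when 4-carboxy replaces 3-carboxy. Among the measured compounds shown here, the methyl present on the entering 4-carboxy-2-methylphenyl has no measured counterpart, so its contribution is unknown. A modest downward step is therefore expected for compound 4, a number 17.9 percentage points lower from compound 1 to compound 4 (beyond the scatter). Compound 4 is estimated at 75%, within a range from 55% to 92%.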

Compound 4, largest response reached (reported as percent of maximum), in percent of the reference or control that the assay uses: 28.4%
Estimate against measurement, compound 4: 46.6 percentage points above, outside the stated range (below it).
By their numbers in this assay, from the lowest: compound 4; then compound 2; then compound 3; then compound 1.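

In this assay, among the compounds shown here, the entry of 4-carboxy-2-methylphenyl on this oxygen gives a number 64.5 percentage points lower from compound 1 to compound 4 (beyond the scatter) and brings the lowest number of the four compounds, so this place tolerates the change far less well than the earlier compounds suggested. This step is large, while a number 18 percentage points higher from compound 2 to compound 3 (beyond the scatter) is modest, so the cyclopentyl ketone of compound 1 offers no protection against the loss of response on this exchange. Nothing shown gives a reason for the size of the step.

Going by these compounds, the split of the step between the shifted carboxylic acid and the added methyl remains open, since the change alters both at once. Also open, on these data alone, is whether chlorine or methoxy in place of that methyl, or an amide in place of the carboxylic acid, would restore the response.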